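Methoxy on the pendant ring and cytotoxicity in cells

The source may hold more compounds than are shown below. What is called first, only, known or untested is meant among the compounds shown, and "the series" means these compounds.

Measured so far in an ADME assay on THP-1 cells (Homo sapiens) for cytotoxicity, read by flow cytometry and propidium iodide staining, with a stated time of 72 h; a higher number here means a weaker inhibitor, a lower number a stronger inhibitor:
compound 1 `CC(=O)Nc1ccc2oc(-c3ccccc3)c(O)c(=O)c2c1` gives 36000 nM
compound 3 `Nc1ccc2oc(-c3ccccc3)c(O)c(=O)c2c1` gives 27000 nM
compound 2 `COc1ccccc1-c1oc2ccc(NC(C)=O)cc2c(=O)c1O` gives only a limit, > 125000 nM

Compound 3 differs from compound 1 by hydrogen in place of acetyl on a nitrogen on an aromatic ring, and a 1.3-fold lower number from compound 1 to compound 3 (0.12 log units; within the scatter). Compound 2 differs from compound 1 by methoxy in place of hydrogen on an aromatic carbon, and an at least 3.4-fold higher number from compound 1 to compound 2 (0.54 log units; beyond the scatter), a step that runs into the limit of > 125000 nM in this assay, at which 1 of the 3 values shown sits, in this assay.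

Compound 4 `COc1ccc(-c2oc3ccc(N)cc3c(=O)c2O)cc1` has not yet been measured. It differs from compound 3 by methoxy in place of hydrogen on an aromatic carbon, the same kind of change as from compound 1 to compound 2, though there the methoxy sits ortho to a large group and here para to a large group. If the step behaves as in an at least 3.4-fold higher number from compound 1 to compound 2 (0.54 log units; beyond the scatter), a higher number for compound 4 is expected, roughly a 2.4-fold higher number from compound 3 to compound 4 (0.38 log units; beyond the scatter), so compound 4 is estimated at 65000 nM, between 25000 nM and 150000 nM, with a fair chance that only a limit is reported.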

Compound 4, half-maximal inhibitory concentration: 29000 nM
Estimate against measurement, compound 4: 2.2-fold (0.35 log units) above, and the stated range covers the measured number.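

In this assay, methoxy para to a large group gives a 1.1-fold higher number from compound 3 to compound 4 (0.03 log units; within the scatter), so the step seen on the other core does not carry over at a fixed size: the same change on two cores in this assay, an at least 3.4-fold higher number (0.54 log units; beyond the scatter) from compound 1 to compound 2 and a 1.1-fold higher number (0.03 log units; within the scatter) from compound 3 to compound 4, at least 3.2-fold (0.50 log units) apart, beyond the scatter of two such steps

This does not show that the core alone decides the outcome, as the methoxy also sits at a different place on the pendant ring in compound 2, so core and place change together. The earlier step also ends at a limit, so its true size stays unknown: the limit of > 125000 nM in this assay, at which 1 of the 4 values shown sits.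

The compounds shown leave open what methoxy does at the place it has in compound 4 when it is carried onto the core of compound 1, and at the place it has in compound 2 on the core of compound 3. They also leave open whether a larger ethoxy group or a chlorine atom at these places would follow the methoxy.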